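From cyclobutyl to methyl on a shared core

A few compounds are considered here, and "the series" means these few. Any claim that something is new, unique, unknown or untested is made for them only; others in the source may bear on it.

Three related compounds have been measured so far in a functional assay (strain AB) with Danio rerio as the target, read by microscopy, with a stated time of 1 h (on this read-out higher numbers stand for an effect only at larger amounts of compound and lower numbers for an effect already at smaller amounts), on this read-out. Compound 1 (`C[N+]1(CC2CCC2)CCc2c(sc(NC(=O)Nc3ccc(Cl)cc3)c2C(N)=O)C1`) gives 210 nM there, the lower of the two actual numbers. Compound 2 (`CC(C)(C)OC(=O)CCCN1CCc2c(sc(NC(=O)Nc3ccc(Cl)cc3)c2C(N)=O)C1`) gives 560 nM in this assay and so stands higher than compound 1 by a gap beyond the usual scatter. Compound 3 (`NC(=O)c1c(NC(=O)Nc2ccc(Cl)cc2)sc2c1CCCC2`) is recorded at > 25000 nM in this assay and that entry is a limit of the assay, not a number.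

Compound 4 (`CC[N+]1(C)CCc2c(sc(NC(=O)Nc3ccc(Cl)cc3)c2C(N)=O)C1`) has not yet been measured. Its change from compound 1 is methyl in place of cyclobutyl on a saturated chain carbon bound to an amine nitrogen in a ring, which also reads as cyclobutylmethyl to ethyl. Among the measured compounds shown here, no measured pair shows this change alone, so the expectation leans on compound 1 at 210 nM and compound 2 at 560 nM as the only numbers available. A modest move to a higher number in this assay is expected, one that may not clear the scatter by much. The expected change is a 2.1-fold higher number from compound 1 to compound 4 (0.33 log units; beyond the scatter) as a working estimate. For compound 4 the estimated value is 450 nM with an expected range from 120 nM to 2000 nM in this measurement.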

Compound 4, half-maximal effective concentration: 1960 nM
Estimate against measurement, compound 4: 4.4-fold (0.64 log units) below; measured number inside the range.
By their numbers in this assay, from the lowest: compound 1; then compound 2; then compound 4. At a limit, above all of these: compound 3.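

In this assay, the place on a saturated chain carbon bound to an amine nitrogen in a ring turns out to be sensitive to what it carries: methyl in place of cyclobutyl gives a 9.3-fold higher number from compound 1 to compound 4 (0.97 log units; beyond the scatter). Among the compounds shown here, this is the first step that isolates a single place, since the earlier compounds differ from one another in more than one, and it ties the lower number of the pair to the cyclobutyl group, which can also be read as cyclobutylmethyl giving way to ethyl. Nothing measured here bears on why the step has this size.

With only cyclobutyl and methyl compared at this place, the compounds shown cannot separate the effect of the four-membered ring from that of the number of carbons, so it remains open whether a cyclopropyl group, a cyclopentyl group or an open butyl chain would stand nearer to compound 1 or to compound 4. Also open, as far as these compounds go, is how a hydroxyl or a carboxylic acid at the end of the chain would read out in this assay.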